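Trifluoromethyl ketone replacing a carboxyphenyl on the oxazole

The compounds below may be only part of what the source reports. "The series", "measured", "known", "first", "only" and "open" are said of these compounds alone.

Compound 1 `COC(=O)c1ccccc1-c1cnc(C(=O)CCCCCCc2ccccc2)o1`: 60 nM
Compound 2 `O=C(O)c1ccc(-c2cnc(C(=O)CCCCCCc3ccccc3)o2)cc1`: 60 nM
Compound 3 `O=C(CCCCCCc1ccccc1)c1ncc(-c2cc(C(F)(F)F)ccn2)o1`: 3.5 nM

In an assay (Rattus norvegicus) for inhibition of Fatty-acid amide hydrolase 1 (Homo sapiens) (a lower number here means a stronger inhibitor, a higher number a weaker inhibitor), compound 2 gives 60 nM, level with compound 1 at 60 nM and together the highest of the three numbers, while compound 3 at 3.5 nM sits well beyond the scatter below them. Compound 4 `O=C(CCCCCCc1ccccc1)c1ncc(C(=O)C(F)(F)F)o1` has not been measured. It differs from compound 2 as follows: (trifluoromethyl)carbonyl in place of 4-carboxyphenyl on an aromatic carbon. Within the data shown here, no measured pair shows this change, so the size of the step is uncertain. Given the spread from compound 2 to compound 3, a moderate step toward a lower number is expected, a 3.0-fold lower number from compound 2 to compound 4 (0.48 log units; beyond the scatter). Compound 4 is therefore estimated at 20 nM, with a range from 4 nM to 100 nM in this assay.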

Compound 4, inhibition constant: 4 nM
Estimate against measurement, compound 4: 5.0-fold (0.70 log units) above, and the stated range covers the measured number.
By their numbers in this assay, from the lowest: compounds 3 and 4 (each within the scatter of the next); then compounds 1 and 2 (each within the scatter of the next).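

In this assay, (trifluoromethyl)carbonyl in place of 4-carboxyphenyl gives a 15-fold lower number from compound 2 to compound 4 (1.18 log units; beyond the scatter) without any ring in the entering group. A six-membered aromatic ring on this carbon, next to the ring oxygen, is therefore not required for a low number, and a smaller group with no ring can serve there. Nothing shown bears on why the step is this large.

The compounds shown leave open whether a plain acetyl group, with hydrogen in place of the fluorine, would match compound 4. Going by these compounds, how a nitrile or an amide would compare at this position also stays open.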